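Amine acylation in the diethylpiperazinyl purine series

A few compounds are considered here, and "the series" means these few. Any claim that something is new, unique, unknown or untested is made for them only; others in the source may bear on it.

Measured compounds: compound 1 `CCN1CCN(CCCn2cnc3c(N4CCN(CC)CC4)nc(N)nc32)CC1` 260 nM; compound 3 `CCN1CCN(CCCn2cnc3c(N4CCN(CC)CC4)nc(NCc4ccc(OC)cc4)nc32)CC1` 200 nM; compound 2 `CCN1CCN(CCCn2cnc3c(N4CCN(C(=O)C5CCCC5)CC4)nc(NCc4ccc(N(CC)CC)cc4)nc32)CC1` 8800 nM.

In an assay on HEK293 cells for antagonist activity at Toll-like receptor 9 (Homo sapiens), read by spectrophotometry (on this read-out higher numbers stand for weaker inhibition and lower numbers for stronger inhibition), compound 3 gives the lowest of the three numbers, but compound 1 sits within the scatter of it, while compound 2 sits far beyond. Within the data shown here, the only single step, a 1.3-fold lower number from compound 1 to compound 3 (0.11 log units; within the scatter), concerns the benzyl nitrogen and is within the scatter. Compound 4 `CCN1CCN(CCCn2cnc3c(N4CCN(C(=O)C5CCCC5)CC4)nc(NCc4ccc(OC)cc4)nc32)CC1` carries cyclopentylcarbonyl in place of ethyl on an amine nitrogen in a ring. Among the measured compounds shown here, no measured single step bears on that change. Compound 2, which also carries the cyclopentylcarbonyl group, gives a much higher number than compound 3, but the two differ in more than one place. A higher number is therefore expected for compound 4, with wide uncertainty: a 15-fold higher number from compound 3 to compound 4 (1.18 log units; beyond the scatter), giving an estimate of 3000 nM within 700 nM to 12000 nM.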

Compound 4, half-maximal inhibitory concentration: > 30000 nM
Compound 4 gave a limit, no number (the forecaster's own chance of this, stated with the estimate: 5%); middle value at least 10-fold (1.00 log units) away from the limit.
By their numbers in this assay, from the lowest: compounds 3 and 1 (each within the scatter of the next); then compound 2. At a limit, above all of these: compound 4.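

In this assay compound 4 reads only as a limit, not a number: the limit of > 30000 nM in this assay, at which 1 of the 4 values shown sits.

Cyclopentylcarbonyl in place of ethyl on this amine nitrogen in a ring gives an at least 150-fold higher number from compound 3 to compound 4 (2.17 log units; beyond the scatter), the first single-place reading at this position, and a large loss of inhibition. With cyclopentylcarbonyl held fixed, methoxy in place of diethylamino on an aromatic carbon gives an at least 3.4-fold higher number from compound 2 to compound 4 (0.53 log units; beyond the scatter), so the group on the benzyl ring also counts in the acylated compounds.

Open, as far as these compounds go, is whether the carbonyl or the cyclopentyl ring carries the loss; acetyl or plain cyclopentyl on that nitrogen would separate the two.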